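The source may hold more compounds than are shown below. What is called first, only, known or untested is meant among the compounds shown, and "the series" means these compounds.

Series notes, following the step from compound 2 to compound 4. The shared core carries a sulfonyl-linked seven-membered ring, and that ring is what varies. Compound 1 `O=C(Nc1ccc(F)c(Cl)c1)c1ccc(F)c(S(=O)(=O)N2CCSCC(O)C2)c1` gives 19000 nM in an ADME assay on HepG2 2.2.15 cells (Homo sapiens) for cytotoxicity, read by luminescence, with a stated time of 3 days; a lower number here means that less compound is tolerated, a higher number that more compound is tolerated. Compound 2 `O=C(Nc1ccc(F)c(Cl)c1)c1ccc(F)c(S(=O)(=O)N2CCOC[C@H](O)C2)c1` gives 19000 nM in this assay and stands level with compound 1 at the digits shown; the step of no change at the digits printed from compound 1 to compound 2 (within the scatter) lies within the scatter. Compound 3 `CN1CCCN(S(=O)(=O)c2cc(C(=O)Nc3ccc(F)c(Cl)c3)ccc2F)CC1=O` returns only a limit in this assay, > 100000 nM. The steps of an at least 5.2-fold higher number from compound 1 to compound 3 (0.72 log units; beyond the scatter) and an at least 5.2-fold higher number from compound 2 to compound 3 (0.72 log units; beyond the scatter) are accordingly at least modest, and one of the three values sits at that limit (the limit of > 100000 nM in this assay, at which 1 of the 3 values shown sits).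

Compound 4 `CC(O)C1CCCCN(S(=O)(=O)c2cc(C(=O)Nc3ccc(F)c(Cl)c3)ccc2F)C1` has not yet been run in this assay. The change is 3-(1-hydroxyethyl)azepan-1-yl in place of 6-hydroxy-1,4-oxazepan-4-yl on a sulfonyl sulfur. The two compounds whose ring carries a hydroxyl, compound 1 and compound 2, sit at the same figure; the ring without one, compound 3, is the one at the limit. Compound 4 keeps a hydroxyl, now in a 1-hydroxyethyl side chain, and loses the second ring hetero atom. For the measured compounds named here, no measured step covers that exchange; the nearest precedent, no change at the digits printed from compound 1 to compound 2 (within the scatter), was flat. The step in this assay is therefore expected to be a 1.1-fold lower number from compound 2 to compound 4 (0.05 log units; within the scatter), within the scatter. Compound 4 is estimated at 17000 nM in this assay, between 6000 nM and 50000 nM, with some chance that only a limit is reported.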

Compound 4, half-maximal cytotoxic concentration: 2600 nM
Compound 4: middle estimate off by 6.5-fold (0.82 log units), on the high side; the whole stated range lies above it.
By their numbers in this assay, from the lowest: compound 4; then compounds 1 and 2 (each within the scatter of the next). At a limit, above all of these: compound 3.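

Notes on the sulfonyl-linked ring: in this assay the shared presence of a hydroxyl no longer goes with a single level, since a 7.3-fold lower number from compound 2 to compound 4 (0.86 log units; beyond the scatter) and a 7.3-fold lower number from compound 1 to compound 4 (0.86 log units; beyond the scatter) even though compound 4 keeps a hydroxyl. The flat exchange of ring hetero atoms seen between compound 1 and compound 2 therefore does not extend to 3-(1-hydroxyethyl)azepan-1-yl, and this place on the sulfonyl sulfur proves sensitive to the group it carries, with compound 4 now lowest of the series. The widest gap is to the hydroxyl-free ring, where an at least 38-fold lower number from compound 3 to compound 4 (1.58 log units; beyond the scatter) and the size of that step is only a bound, as the value of compound 3 is a limit: the limit of > 100000 nM in this assay, at which 1 of the 4 values shown sits.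

The exchange in compound 4 alters the ring hetero atoms, the heavy-atom count and the placing of the hydroxyl all at once, so the compounds shown do not say which of these changes goes with the lower number. An azepan-1-yl with no substituent, or one carrying a plain hydroxyl or an amine on the ring, would begin to separate these contributions.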